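Methoxy to Chloro: One Change Tried in Two Settings

The source may hold more compounds than are shown below. What is called first, only, known or untested is meant among the compounds shown, and "the series" means these compounds.

Compound 1 `CCCCC#Cc1c(C)[nH]c2ccc(OC)cc2c1=O`: 5.25
Compound 2 `CCCCC#Cc1c(C)[nH]c2ccc(Cl)cc2c1=O`: 2.98
Compound 3 `COc1ccc2c(c1)c(=O)c(Cc1ccccc1)c(C)n2C`: 2.73

The three measured compounds were all tested in a physicochemical assay for lipophilicity, at pH 7.4; a lower number here means a more polar compound, a higher number a more lipophilic compound. Compound 1 and compound 2 share one core and differ in a single place: chloro in place of methoxy on an aromatic carbon. That change produced a number 2.27 log units lower from compound 1 to compound 2 (beyond the scatter), so within this pair the chloro compound sits far below its methoxy partner.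

Compound 3 belongs to a different core. How the core of compound 3 differs from the core of compound 1 is not broken down here. In this assay compound 3 gives the lowest of the three numbers; compared with compound 2 the gap is within the scatter, while compared with compound 1 it is well beyond it.

Compound 4 `Cc1c(Cc2ccccc2)c(=O)c2cc(Cl)ccc2n1C` has not yet been measured. It differs from compound 3 in exactly one place: chloro in place of methoxy on an aromatic carbon. The place is described in the same words for both pairs, so this is the same change seen between compound 1 and compound 2, now made on the other core.

Among the compounds with values here, with only that one earlier instance to go on, the expectation for compound 4 is a drop in the same direction, and the estimated step is a number 1.73 log units lower from compound 3 to compound 4 (beyond the scatter), because the earlier change gave a number 2.27 log units lower from compound 1 to compound 2 (beyond the scatter). Whether the size carries over to a different core cannot be known from a single example, so the range is kept wide. The estimate for compound 4 in this assay is 1, between -0.3 and 2.9.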

Compound 4, distribution coefficient: 3.21
Compound 4: middle estimate off by 2.21 log units, on the low side; the whole stated range lies below it.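

In this assay, replacing methoxy with chloro on the core of compound 3 gave a number 0.48 log units higher from compound 3 to compound 4 (beyond the scatter) while the same replacement on the core of compound 1 gave a number 2.27 log units lower from compound 1 to compound 2 (beyond the scatter) and so the step changed direction as well as size when moved to the other core. This shows that, across these two pairs, neither the size nor the direction of the change carries over from one core to the other, but with a single pair on each core it does not show which step is more typical or which part of the core matters. Nothing available here explains why the two steps differ.

The compounds shown leave open how the same replacement would behave on a third core, or on cores that differ from one another in only one feature, which would help locate the source of the reversal. They also leave open whether another group on that aromatic carbon, such as fluoro, an amine or a carboxylic acid, would likewise give steps that differ between the two cores.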